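Changing one ring of compound 2

The compounds below may be only part of what the source reports. "The series", "measured", "known", "first", "only" and "open" are said of these compounds alone.

Measured so far in a functional assay on SW480 cells (Homo sapiens) for antiproliferative activity, read by sulforhodamine B assay, with a stated time of 48 h (a lower number here means a stronger inhibitor, a higher number a weaker inhibitor), are two compounds.

Compound 1 `COc1ccc(/C=C/C(=O)c2ccccc2-c2cccnc2)cc1` gives 200 nM
Compound 2 `COc1ccc(C(=O)/C=C/c2ccccc2-c2ccc(F)cc2)cc1` gives 8400 nM

Of these two numbers, compound 2 has the higher one, which makes it the weaker inhibitor, and its gap to compound 1 lies beyond the usual scatter of repeated measurements. The next compound to be tested is compound 3 (`COc1ccc(C(=O)/C=C/c2ccccc2-c2ccc(F)nc2)cc1`). It matches compound 2 except at one place, where 6-fluoropyridin-3-yl stands in place of 4-fluorophenyl on an aromatic carbon (6-fluoropyridin-3-yl in place of 4-fluorophenyl on an aromatic carbon). Going by the values given here, no pair of tested compounds shows what a change of this kind does on its own. Compound 1 at 200 nM also carries an aromatic ring with a hetero atom, but its structure differs from compound 2 elsewhere too, so it offers only a weak hint. A modest fall in the number is therefore expected, and it may not clear the scatter. The estimated change is a 2.4-fold lower number from compound 2 to compound 3 (0.38 log units; beyond the scatter) in this assay and remains uncertain. Compound 3 is expected at 3500 nM with an estimated range from 800 nM to 12000 nM in this assay when tested.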

Compound 3, half-maximal inhibitory concentration: 10000 nM
Estimate against measurement, compound 3: 2.9-fold (0.46 log units) below; measured number inside the range.
By their numbers in this assay, from the lowest: compound 1; then compounds 2 and 3 (each within the scatter of the next).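

In this assay, putting 6-fluoropyridin-3-yl in place of 4-fluorophenyl, on an aromatic carbon ortho to a large group, gives a 1.2-fold higher number from compound 2 to compound 3 (0.08 log units; within the scatter), so the two compounds cannot be told apart. Going by these compounds alone, this is the first pair that isolates the change, and it shows that on this core, swapping a ring of carbon only for a ring with one hetero atom, which also brings one hydrogen-bond acceptor by count, moves the number no further than repeated measurements would. Nothing measured here explains why the swap leaves the number within the scatter, and compound 1 differs from both compounds in more than one place, so it cannot settle the point.

On these data alone, the pair covers only rings that carry fluorine, so it remains open whether a pyridin-3-yl ring without the fluorine would behave the same way on this core, or whether the same swap would matter on the core of compound 1. As far as these compounds go, it is also open what an amine or a carboxylic acid in place of the fluorine on this ring would do to the number.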